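This account rests on a few compounds, and the source may have more. Where it says the series, first, only, none or still open, it means among the compounds named here.

Within the data shown here, in a functional assay for inhibition, with Homo sapiens as the target (a lower number here means a stronger inhibitor, a higher number a weaker inhibitor), compound 1 `COC(C)c1cc(-c2ccccc2)c2ccc(OCc3cccc(C4(O)CCOCC4)c3)cc2c1` gives 41 nM and compound 2 `CC(=O)c1cc(-c2ccccc2)c2ccc(OCc3cccc(C4(O)CCOCC4)c3)cc2c1` gives 2 nM, the lowest number so far. Next is compound 3 `N#Cc1cc(-c2ccccc2)c2ccc(OCc3cccc(C4(O)CCOCC4)c3)cc2c1`, with cyano in place of acetyl on an aromatic carbon. Among the measured compounds shown here, only one measured step bears on this carbon, a 21-fold lower number from compound 1 to compound 2 (1.31 log units; beyond the scatter). It is a large step, but it does not involve cyano, so it gives only weak guidance. A modest move towards a higher number is expected in this assay, possibly within the scatter. The estimated value for compound 3 is 5 nM, with an expected range of 1.5 nM to 20 nM. The expected change is a 2.5-fold higher number from compound 2 to compound 3 (0.40 log units; beyond the scatter).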

Compound 3, half-maximal inhibitory concentration: 3 nM
The estimate for compound 3 lay 1.7-fold (0.22 log units) above the measured number; low and high end bracket the measured number.
By their numbers in this assay, from the lowest: compounds 2 and 3 (each within the scatter of the next); then compound 1.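

In this assay, cyano in place of acetyl on this aromatic carbon gives a 1.5-fold higher number from compound 2 to compound 3 (0.18 log units; within the scatter), so the acetyl carbonyl is not needed for a number in this range. Cyano in place of 1-methoxyethyl gives a 14-fold lower number from compound 1 to compound 3 (1.14 log units; beyond the scatter), so the large gap to compound 1 now holds for two different groups, not for acetyl alone. Nothing available gives a reason for either step.

Open, as far as these compounds go, is whether an amide, a carboxylic acid or an amine on this carbon fits the same range. Also open, from the compounds shown here alone, is whether a longer chain bearing a ketone or a nitrile does.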